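This account rests on a few compounds, and the source may have more. Where it says the series, first, only, none or still open, it means among the compounds named here.

Measured so far:
compound 1 `COc1ccc(C(=O)Nc2cccc(-c3ccnc4c(NC(C)=O)cccc34)c2)cc1OC` — 5300 nM in a functional assay on A375P cells (Homo sapiens) for antiproliferative activity, read by MTT assay, with a stated time of 48 h; a lower number here means a stronger inhibitor, a higher number a weaker inhibitor
compound 2 `CC(=O)Nc1cccc2c(-c3cccc(NC(=O)c4cc(Cl)cc(C(F)(F)F)c4)c3)ccnc12` — 6200 nM in this assay

Both numbers are in the same range: the step of a 1.2-fold higher number from compound 1 to compound 2 (0.07 log units; within the scatter) is within the scatter, so compound 2 and compound 1 cannot be told apart on these data.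

Compound 3 `CC(=O)Nc1cccc2c(-c3cccc(NC(=O)c4nccs4)c3)ccnc12` is the next change on the carbonyl carbon: 1,3-thiazol-2-yl in place of 3-chloro-5-(trifluoromethyl)phenyl on a carbonyl carbon. Among the measured compounds shown here, only one measured step bears on it, the exchange of the aryl on the same carbonyl from compound 1 to compound 2, and that step was within the scatter. A step of similar size, in no firm direction, is therefore expected as a 1.0-fold lower number from compound 2 to compound 3 (0.01 log units; within the scatter). Compound 3 is estimated at 6000 nM, with a range from 2500 nM to 15000 nM.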

Compound 3, half-maximal inhibitory concentration: > 20000 nM
Compound 3 was reported as a limit; the forecaster's own chance of this, stated with the estimate: 10%; at least 3.3-fold (0.52 log units) between middle value and limit.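

Exchanging the aryl on this carbonyl carbon is not neutral after all: 1,3-thiazol-2-yl gives an at least 3.2-fold higher number from compound 2 to compound 3 (0.50 log units; beyond the scatter) and an at least 3.7-fold higher number from compound 1 to compound 3 (0.57 log units; beyond the scatter), while the earlier aryl exchange could not be resolved. In this assay, compound 3 is reported only as a limit, not as a number: the limit of > 20000 nM in this assay, at which 1 of the 3 values shown sits.

So the true size of both steps stays unknown, and only their direction is fixed. From the compounds shown here alone, these compounds do not separate the smaller five-membered ring from its hetero atoms, and an unsubstituted phenyl or a saturated amine such as piperidine on this carbonyl remains open.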